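The compounds below may be only part of what the source reports. "The series", "measured", "known", "first", "only" and "open" are said of these compounds alone.

Compound 1 `COc1cc(-n2ncnc2-c2cccc([N+](=O)[O-])c2)cc(OC)c1OC` gives > 10000 nM in a functional assay on A549 cells (Homo sapiens) for antiproliferative activity, read by MTT assay, with a stated time of 72 h (on this read-out lower numbers stand for stronger inhibition and higher numbers for weaker inhibition), which is a limit of the assay and not a number.
Compound 2 `COc1ccc(-n2ncnc2-c2cc(OC)c(OC)c(OC)c2)cc1` gives > 10000 nM in this assay, again a limit rather than a number.
Compound 3 `COc1cc(-c2ncnn2-c2ccc(N)cc2)cc(OC)c1OC` gives > 10000 nM in this assay, also only a limit.

Compound 1 therefore stands nowhere in particular on the scale: there is no number for it, only a limit, and the same holds for every value shown (the limit of > 10000 nM in this assay, at which 3 of the 3 values shown sit). Among the measured compounds shown here, the one comparison between measured compounds, from compound 2 to compound 3 a step that the two limits leave unreadable from compound 2 to compound 3, changes amino in place of methoxy on an aromatic carbon, but with both ends at the limit its size cannot be read.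

Compound 4 `COc1cccc(-c2ncnn2-c2cc(OC)c(OC)c(OC)c2)c1` is the compound still to be measured. It differs from compound 1 as follows: methoxy in place of nitro on an aromatic carbon. No measured step involves methoxy in place of nitro, so nothing shown speaks directly to this change, and the single measured step is itself unreadable. The expectation for compound 4 can rest only on the fact that every value shown sits at the limit (the limit of > 10000 nM in this assay, at which 3 of the 3 values shown sit), so compound 4 is estimated to fall at 15000 nM, within 5000 nM to 50000 nM. The step from compound 1 to compound 4 is expected to be a step that the limit leaves unreadable from compound 1 to compound 4, meaning most likely another limit rather than a measurable shift in either direction.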

Compound 4, half-maximal inhibitory concentration: > 10000 nM
Compound 4 was reported as a limit (the forecaster's own chance of this, stated with the estimate: 75%); the middle value is on the limit's open side.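

Compound 1 and compound 4 both sit at a limit rather than a number, so the size of the change from nitro to methoxy cannot be read, and no new step emerges: the limit of > 10000 nM in this assay, at which 4 of the 4 values shown sit.

The compounds shown leave open whether any change to these structures gives a measurable value in this assay.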